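Cyclic bis-arylidene ketones with triazolylmethyl groups: cytotoxicity notes

This account rests on a few compounds, and the source may have more. Where it says the series, first, only, none or still open, it means among the compounds named here.

Measured so far in a functional assay on MCF7 cells (Homo sapiens) for cytotoxicity, read by MTT assay, with a stated time of 24 h; a lower number here means a stronger inhibitor, a higher number a weaker inhibitor:
compound 1, `O=C1/C(=C/c2ccccc2F)CN(C(=S)SCc2cn(Cc3cccc(Cl)c3)nn2)C/C1=C\c1ccccc1F`, gives > 100000 nM, which is a limit of the assay and not a number
compound 2, `COc1ccc(/C=C2\CN(Cc3cn(Cc4cccc(Cl)c4)nn3)C/C(=C\c3ccc(OC)cc3)C2=O)cc1`, gives 99000 nM
compound 3, `Cc1ccc(/C=C2\CN(Cc3cn(Cc4ccc(F)cc4)nn3)C/C(=C\c3ccc(C)cc3)C2=O)cc1`, gives 29000 nM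

Compound 1 sits at the limit of > 100000 nM in this assay, at which 1 of the 3 values shown sits, so only a limit is known for it. Among the two numbers read, compound 2 stands highest; compound 3 gives the lower number, and the gap between the two is beyond the scatter. Going by the values given here, no pair of measured compounds differs in a single place, so no measured step is available. Compound 4, `COc1ccc(/C=C2\CN(Cc3cn(Cc4ccccc4F)nn3)C/C(=C\c3ccc(OC)cc3)C2=O)cc1`, has not been measured. It differs from compound 2 in one place: 2-fluorophenyl in place of 3-chlorophenyl on a saturated chain carbon bound to an aromatic nitrogen. Among the compounds with values here, nothing among the measured compounds isolates this change; compound 1 carries a 2-fluorophenyl and compound 3 a 4-fluorophenyl, but each also differs from compound 2 elsewhere. The step from compound 2 to compound 4 is therefore expected to be small, with no confident direction, most likely within the scatter, as a 1.1-fold lower number from compound 2 to compound 4 (0.04 log units; within the scatter). In this assay compound 4 is expected to give about 90000 nM, between 30000 nM and 300000 nM, with a real chance that only a limit is read.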

Compound 4, half-maximal inhibitory concentration: >= 100000 nM
Compound 4: only a limit was reported; the forecaster's own chance of this, stated with the estimate: 40%; middle value at least 1.1-fold (0.04 log units) from the limit.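

This gives the series its first single-place comparison. With 2-fluorophenyl in place of 3-chlorophenyl on a saturated chain carbon bound to an aromatic nitrogen, this assay shows a number no lower from compound 2 to compound 4 (the limit leaves the size open). For compound 4 the reading is a limit of the assay and not a number: the limit of >= 100000 nM in this assay, at which 1 of the 4 values shown sits. The change therefore brings no lowering at this position, though how far the number rises, if at all, cannot be read.

Compound 3 differs from compound 2 in more than one place, so in compound 3 the groups behind 29000 nM cannot be separated. On these data alone, whether an amine or a carboxylic acid on this phenyl ring, or a longer chain in place of the benzyl link, would give a readable number remains open.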